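A Swap on the Amine Nitrogen in a Weak Set

The source may hold more compounds than are shown below. What is called first, only, known or untested is meant among the compounds shown, and "the series" means these compounds.

Compound 1 `O=C1C(Nc2ccccc2)=CC(=O)c2c1nc1n2[C@H]2OC[C@@H](O)[C@H]2OC1`, compound 2 `O=C1C(Nc2ccc(C(F)(F)F)cc2)=CC(=O)c2c1nc1n2[C@H]2OC[C@@H](O)[C@H]2OC1` and compound 3 `COc1ccc(NC2=CC(=O)c3c(nc4n3[C@H]3OC[C@@H](O)[C@H]3OC4)C2=O)cc1` share one core and differ in the group on the amine nitrogen. In a functional assay on HeLa cells (Homo sapiens) for inhibition, read by sulforhodamine B assay (a higher number here means a weaker inhibitor, a lower number a stronger inhibitor), compound 3 gives > 8000 nM as its reading, which is a limit and not a number. Compound 1 gives > 8000 nM as its reading, also a limit. Compound 2 gives 8920 nM as a measured number. Compound 4 `CCOc1ccccc1NC1=CC(=O)c2c(nc3n2[C@H]2OC[C@@H](O)[C@H]2OC3)C1=O` has 2-ethoxyphenyl in place of 4-methoxyphenyl on an amine nitrogen. The nearest measured steps are (a step that the two limits leave unreadable from compound 1 to compound 3), (a step that the limit leaves unreadable from compound 2 to compound 3) and (a step that the limit leaves unreadable from compound 1 to compound 2), and none has a readable size. No step beyond the scatter is therefore expected in this assay, and no direction can be given, so the estimated change is (a step that the limit leaves unreadable from compound 3 to compound 4). For compound 4 the estimate is 9000 nM (expected range 4000 nM to 20000 nM).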

Compound 4, half-maximal inhibitory concentration: 8300 nM
Compound 4: middle estimate off by 1.1-fold (0.04 log units), on the high side; the range from low to high includes it.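

Going by these compounds alone, with compound 4, this assay gains a second measured number, and 2-ethoxyphenyl in place of 4-(trifluoromethyl)phenyl gives the first readable step at this position: a 1.1-fold lower number from compound 2 to compound 4 (0.03 log units; within the scatter). Two different substituted phenyl groups on the amine nitrogen thus read alike here. The other steps cannot be read, because the readings of compound 1 and compound 3 are limits: the limit of > 8000 nM in this assay, at which 2 of the 4 values shown sit.

As far as these compounds go, whether a carboxylic acid or an amine on that phenyl ring, or a benzyl group in its place, would shift the reading remains open.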